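This account rests on a few compounds, and the source may have more. Where it says the series, first, only, none or still open, it means among the compounds named here.

The three measured compounds share one core and differ only in the side chain: compound 1 `CC[C@H](C)[C@H](NC(=O)CN(c1ncnc2c1ncn2C1CCCCO1)C1CC1)C(=O)OCc1ccccc1`, compound 2 `C[C@@H](O)[C@H](NC(=O)CN(c1ncnc2c1ncn2C1CCCCO1)C1CC1)C(=O)OCc1ccccc1` and compound 3 `O=C(CN(c1ncnc2c1ncn2C1CCCCO1)C1CC1)N[C@@H](CC(=O)OCc1ccccc1)C(=O)OCc1ccccc1`. In a functional assay on the whole organism (Tail, strain ICR) with Mus musculus as the target, in the tail flick test, with a stated time of 90 min, at a dose of 25 umol/kg by the oral route (a lower number here means a weaker effect, a higher number a stronger effect of the compound at the dose given), compound 1 gives 22.6%. Compound 2 gives 23.4%, and compound 3 gives 25.1%. Compound 3 carries the highest of the three numbers, but its gaps to compound 2 and to compound 1 lie within the scatter, so no order can be read from them. The side-chain steps are a number 2.5 percentage points higher from compound 1 to compound 3 (within the scatter) and a number 1.7 percentage points higher from compound 2 to compound 3 (within the scatter), and a number 0.8 percentage points higher from compound 1 to compound 2 (within the scatter) likewise stays within the scatter. Compound 4 `CSCC[C@H](NC(=O)CN(c1ncnc2c1ncn2C1CCCCO1)C1CC1)C(=O)OCc1ccccc1` is not yet measured; it differs from compound 3 by (methylsulfanyl)methyl in place of benzyloxycarbonyl on a saturated chain carbon, two bonds along the chain from an amide-type nitrogen and a carbonyl carbon. Going by the values given here, every exchange at the side chain so far has left this assay unmoved beyond the scatter, and nothing among the measured compounds argues for a step of another size here. The expected step is therefore a number 1.6 percentage points lower from compound 3 to compound 4 (within the scatter), none beyond the scatter. Compound 4 is estimated at 23.5%, with a range from 13% to 34%.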

Compound 4, a percentage reported as activity, at one dose (the size of the read-out at that dose, not a potency): 42.7%
Beside the measured number, compound 4's estimate is 19.2 percentage points below it; measured number outside the range, above it.
By their numbers in this assay, from the lowest: compounds 1, 2 and 3 (each within the scatter of the next); then compound 4.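

Going by these compounds alone, at this side-chain position, 2-(methylsulfanyl)ethyl is the first group to move this assay beyond the scatter, with modest steps of a number 17.6 percentage points higher from compound 3 to compound 4 (beyond the scatter) and a number 19.3 percentage points higher from compound 2 to compound 4 (beyond the scatter) and a number 20.1 percentage points higher from compound 1 to compound 4 (beyond the scatter) while sec-butyl, 1-hydroxyethyl and (benzyloxycarbonyl)methyl remain within the scatter of one another. The position is therefore not indifferent to the group it carries, although compound 4 alone shows this, and the pattern extends no further than these four compounds. No measurement bears on the origin of this step.

The compounds shown do not separate a contribution of the sulfur atom from that of the chain carrying it. A plain n-butyl chain, a 2-methoxyethyl chain or a longer thioether chain at this position would address that question.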